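Series notes: the step from compound 2 to compound 4

The source may report more compounds than this note shows. Statements on the series, on what has been measured and on what is new or still open speak of the compounds shown alone.

Compound 1 `CCOc1ccc(-n2cc(C(=O)c3ccc(OC)cc3O)ccc2=O)cc1` returns only a limit in an ADME assay on HepG2 2.2.15 cells (Homo sapiens) for cytotoxicity, read by CCK-8 assay, with a stated time of 8 days (a lower number here means that less compound is tolerated, a higher number that more compound is tolerated), > 100000 nM. Within the data shown here, of the two numerical values, compound 2 `COc1ccc(-c2cc(NC(=O)c3cccc(OC)c3O)c[nH]c2=O)cc1` gives 49200 nM and compound 3 `COc1ccc(-c2cc(NC(=O)c3ccc(Cl)cc3O)c[nH]c2=O)cc1` gives 50500 nM, so compound 2 stands level with its only measured neighbour. Compound 4 `COc1ccc(-c2cc(NC(=O)c3ccc(C)cc3O)c[nH]c2=O)cc1` differs from compound 2 by one change on a carbonyl carbon: 2-hydroxy-4-methylphenyl in place of 2-hydroxy-3-methoxyphenyl on a carbonyl carbon. Among the measured compounds shown here, the one measured step bearing on this is the exchange for 4-chloro-2-hydroxyphenyl at the same place, a 1.0-fold higher number from compound 2 to compound 3 (0.01 log units; within the scatter). No step beyond the scatter is therefore expected in this assay. The expected step is a 1.0-fold higher number from compound 2 to compound 4 (0.01 log units; within the scatter). For compound 4 the estimated value is 50000 nM, with an expected range of 25000 nM to 100000 nM.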

Compound 4, half-maximal cytotoxic concentration: 46100 nM
Beside the measured number, compound 4's estimate is 1.1-fold (0.04 log units) above it; the range from low to high includes it.
By their numbers in this assay, from the lowest: compounds 4, 2 and 3 (each within the scatter of the next). At a limit, above all of these: compound 1.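

In this assay a third group on this carbonyl carbon brings no step beyond the scatter: a 1.1-fold lower number from compound 2 to compound 4 (0.03 log units; within the scatter). Methyl in place of chloro on an aromatic carbon also stays within it: a 1.1-fold lower number from compound 3 to compound 4 (0.04 log units; within the scatter). The 2-hydroxy-3-methoxyphenyl, 4-chloro-2-hydroxyphenyl and 2-hydroxy-4-methylphenyl groups of compound 2, compound 3 and compound 4 therefore read alike here.

As far as these compounds go, whether this holds for an amine or a carboxylic acid on that aromatic ring remains open. Compound 1 gives only a limit and offers no comparison with these amides: the limit of > 100000 nM in this assay, at which 1 of the 4 values shown sits.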